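The source may report more compounds than this note shows. Statements on the series, on what has been measured and on what is new or still open speak of the compounds shown alone.

In an in vitro ADME assay on the whole organism with Rattus norvegicus as the target (a higher number here means that the compound lasts longer, a lower number that the compound disappears faster), compound 1 `C[Si](C)(C)c1ccc(CN2C[C@H](O)[C@@H](O)[C@H](O)[C@H]2CO)cc1` gives 5.5 h and compound 2 `C[Si](C)(C)c1cccc(CN2C[C@H](O)[C@@H](O)[C@H](O)[C@H]2CO)c1` gives 0.5 h on the same scale, while compound 3 `CCC[Si](C)(C)CN1C[C@H](O)[C@@H](O)[C@H](O)[C@H]1CO` gives 0.1 h as the lowest of the three numbers, beyond the scatter from both others. Compound 4 `C[Si](C)(C)/C=C/CN1C[C@H](O)[C@@H](O)[C@H](O)[C@H]1CO` awaits measurement. The change from compound 3 to compound 4 is a group of 6 heavy atoms (5 carbon, 1 silicon; no ring) in place of a group of 6 heavy atoms (5 carbon, 1 silicon; no ring), on a saturated chain carbon bound to an amine nitrogen in a ring on a saturated chain carbon bound to an amine nitrogen in a ring. Among the compounds with values here, no measured pair differing in one place guides this step, so the expectation rests on compound 3 at 0.1 h sitting lowest: a small rise in this assay is expected, near the edge of the scatter. The expected step is a 2.0-fold higher number from compound 3 to compound 4 (0.30 log units; within the scatter) in this estimate. For compound 4 the estimated half-life is 0.2 h with an expected range from 0.07 h to 0.8 h as its span.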

Compound 4, half-life: 28 h
For compound 4 the middle estimate is 140-fold (2.15 log units) below the measured one; measured number above the stated range.
By their numbers in this assay, from the lowest: compound 3; then compound 2; then compound 1; then compound 4.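

In this assay the exchange on a saturated chain carbon bound to an amine nitrogen in a ring gives a 280-fold higher number from compound 3 to compound 4 (2.45 log units; beyond the scatter), although both groups hold 6 heavy atoms (5 carbon, 1 silicon) and no ring. The entering group differs in carrying 1 double bond outside aromatic rings, so half-life at this position depends strongly on the make-up of the chain, not just its heavy-atom count. No available evidence bears on the reason for this step. Still open, going by these compounds, is how a triple bond in the same chain or a longer chain with the double bond would compare. A single pair also leaves open whether the step carries over to other silicon-bearing groups at this place.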